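Chloro in place of methanesulfonamido

This account rests on a few compounds, and the source may have more. Where it says the series, first, only, none or still open, it means among the compounds named here.

compound 1 `CCSC(=S)SCC(=O)c1ccc(NS(C)(=O)=O)cc1` gives 39800 nM
compound 2 `CCSC(=S)SCC(=O)c1cccc(OC)c1` gives 5010 nM

In a functional assay on HeLa cells (Homo sapiens) for antiproliferative activity, read by resazurin assay (a lower number here means a stronger inhibitor, a higher number a weaker inhibitor), compound 1 gives 39800 nM, the higher of the two numbers and beyond the scatter from the other. Compound 3 `CCSC(=S)SCC(=O)c1ccc(Cl)cc1` has chloro in place of methanesulfonamido on an aromatic carbon. For the measured compounds named here, no measured pair shows this change. Going by the values given here, the only guide is compound 2 at 5010 nM, which also lacks methanesulfonamido. In this assay a step to a lower number, beyond the scatter, is expected, estimated as an 8.0-fold lower number from compound 1 to compound 3 (0.90 log units; beyond the scatter) here. For compound 3 the estimated value is 5000 nM (expected range 1600 nM to 16000 nM).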

Compound 3, half-maximal inhibitory concentration: 5010 nM
Compound 3: middle estimate off by 1.0-fold (0.00 log units), on the low side; low and high end bracket the measured number.
By their numbers in this assay, from the lowest: compounds 2 and 3 (each within the scatter of the next); then compound 1.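

Chloro in place of methanesulfonamido on an aromatic carbon gives a 7.9-fold lower number from compound 1 to compound 3 (0.90 log units; beyond the scatter) in this assay, the first comparison in the series that changes this one place while the rest of the core stays the same. This place on the ring therefore does not need methanesulfonamido for activity in this series. Nothing at hand gives a reason for the step.

Going by these compounds, whether the step comes from adding chloro or from losing methanesulfonamido remains open. A single pair cannot settle this, and fluoro, an amine or a carboxylic acid at this place would help separate the two.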